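A few compounds are considered here, and "the series" means these few. Any claim that something is new, unique, unknown or untested is made for them only; others in the source may bear on it.

Measured so far in a functional assay on Colon 26 cells (Homo sapiens) for cytotoxicity against Colon 26 (Mus musculus); on this read-out lower numbers stand for stronger inhibition and higher numbers for weaker inhibition:
compound 1 `COc1ccc(-c2sc(N)nc2-c2cc(OC)c(OC)c(OC)c2)cc1N` gives 57.5 nM;
compound 2 `COc1ccc(-c2scnc2-c2cc(OC)c(OC)c(OC)c2)cc1N` gives 14.5 nM;
compound 3 `COc1ccc(-c2nncn2-c2cc(OC)c(OC)c(OC)c2)cc1N` gives 840 nM.

Compound 1 and compound 2 share a core; the difference between the core of compound 2 and the core of compound 3 is not broken down here. Within the shared core, amino in place of hydrogen on an aromatic carbon gave a 4.0-fold higher number from compound 2 to compound 1 (0.60 log units; beyond the scatter). Compound 4 `COc1ccc(-c2nnc(N)n2-c2cc(OC)c(OC)c(OC)c2)cc1N` has not yet been measured in this assay. It arises from compound 3 by the same kind of change, (amino in place of hydrogen on an aromatic carbon), though the surroundings differ: in compound 1 the amino sits next to the ring nitrogen and next to the ring sulfur, whereas in compound 4 it sits between two ring nitrogen atoms, next to the ring atom that bears a large group. Going by the values given here, compound 4 is expected to show a 3.3-fold higher number from compound 3 to compound 4 (0.52 log units; beyond the scatter), a step of similar size and direction to the one between compound 2 and compound 1, because the earlier amino step gave a 4.0-fold higher number from compound 2 to compound 1 (0.60 log units; beyond the scatter). The estimate for compound 4 is therefore 2800 nM, likely between 900 nM and 9000 nM.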

Compound 4, half-maximal inhibitory concentration: > 3000 nM
Compound 4 was reported as a limit; the forecaster's own chance of this, stated with the estimate: 10%; at least 1.0-fold (0.02 log units) between middle value and limit.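

In this assay, amino in place of hydrogen on an aromatic carbon gave a higher number on both cores, and on the second core the step is an at least 3.5-fold higher number from compound 3 to compound 4 (0.55 log units; beyond the scatter). Compound 4 is reported only as a limit, > 3000 nM. The change therefore carried over from one core to the other in direction, but its size on the second core remains unfixed: the same change on two cores in this assay, a 4.0-fold higher number (0.60 log units; beyond the scatter) from compound 2 to compound 1 and an at least 3.5-fold higher number (0.55 log units; beyond the scatter) from compound 3 to compound 4; the limit leaves it open whether they differ

The compounds shown leave open how a methyl group, a hydroxyl group or a longer amine chain would behave at this place on either core. They also leave open whether any group there could give a lower number than hydrogen does in compound 2 and compound 3.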